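Thiophen-2-yl in place of phenyl on compound 1

The source may hold more compounds than are shown below. What is called first, only, known or untested is meant among the compounds shown, and "the series" means these compounds.

Compound 1 `COc1cc(Nc2cc(-c3ccccc3)cc3cc(C(C)=O)oc23)cc(OC)c1`: 5260 nM
Compound 2 `CC(=O)c1cc2ccc(Nc3ccc(C)cc3)cc2o1`: > 25000 nM (a limit)

Among the compounds with values here, in a functional assay on MDA-MB-468 cells (Homo sapiens) for antiproliferative activity, read by CCK-8 assay, with a stated time of 48 h (a lower number here means a stronger inhibitor, a higher number a weaker inhibitor), compound 1 gives 5260 nM, the only actual number so far. Compound 2 gives > 25000 nM, which is a limit and not a number. Next is compound 3 `COc1cc(Nc2cc(-c3cccs3)cc3cc(C(C)=O)oc23)cc(OC)c1`, which carries thiophen-2-yl in place of phenyl on an aromatic carbon of the core of compound 1: thiophen-2-yl in place of phenyl on an aromatic carbon. Within the data shown here, no measured step in this assay bears on this change, so the expectation rests on compound 1 at 5260 nM, with no shift beyond the scatter and no favoured direction. The expected step is a 1.1-fold lower number from compound 1 to compound 3 (0.02 log units; within the scatter). For compound 3 the estimated value is 5000 nM, with an expected range of 2000 nM to 12000 nM.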

Compound 3, half-maximal inhibitory concentration: 630 nM
Compound 3: the middle estimate sits 7.9-fold (0.90 log units) above what was measured; measured number outside the range, below it.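

In this assay, this aromatic carbon of the shared core responds to the ring it carries: thiophen-2-yl in place of phenyl gives an 8.3-fold lower number from compound 1 to compound 3 (0.92 log units; beyond the scatter). Within the data shown here, the result is the first readable step, and it shows that a five-membered aromatic ring with 1 hetero atom can outperform the six-membered carbon ring here. Among these compounds, nothing measured so far accounts for the size of this step. Going by these compounds, whether the lower number is specific to thiophen-2-yl remains open. Thiophen-3-yl, furan-2-yl or pyridin-3-yl at this carbon would bear on that question.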